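Dimethylamino in place of 2-aminoethyl on the shared core

The source may hold more compounds than are shown below. What is called first, only, known or untested is meant among the compounds shown, and "the series" means these compounds.

Compound 1 `CN1CCN(CCCNc2nc(-c3ccc(Cl)cc3)nc3ccccc23)CC1` gives "nd" (no result reported)
Compound 2 `NCCCCNc1nc(-c2ccc(Cl)cc2)nc2ccccc12` gives 13000 nM

Within the data shown here, in a toxicity assay on cells (Macrophage, Homo sapiens) for inhibition, read by MTT assay (on this read-out higher numbers stand for weaker inhibition and lower numbers for stronger inhibition), compound 2 gives 13000 nM as the only number available. Going by these compounds, with no result for compound 1, it cannot be ranked against anything, so its standing remains open.

Compound 3 `CN(C)CCNc1nc(-c2ccc(Cl)cc2)nc2ccccc12` has yet to be measured. Its difference from compound 2 is dimethylamino in place of 2-aminoethyl on a saturated chain carbon, two bonds along the chain from a nitrogen on an aromatic ring and consists of dimethylamino in place of 2-aminoethyl on a saturated chain carbon, two bonds along the chain from a nitrogen on an aromatic ring.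

Among the measured compounds shown here, no measured step between related compounds is available to guide the expectation, which therefore rests on compound 2 at 13000 nM alone. In this assay the expected change is a 1.3-fold lower number from compound 2 to compound 3 (0.11 log units; within the scatter) and this is not expected to go beyond the usual scatter in either direction. Compound 3 is estimated at 10000 nM within a range of 3000 nM to 30000 nM in this expected reading.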

Compound 3, half-maximal inhibitory concentration: 60000 nM
Estimate against measurement, compound 3: 6.0-fold (0.78 log units) below; the measured number lies above the stated range.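

In this assay, dimethylamino in place of 2-aminoethyl on a saturated chain carbon, two bonds along the chain from a nitrogen on an aromatic ring, gives a 4.6-fold higher number from compound 2 to compound 3 (0.66 log units; beyond the scatter). This shows that the read-out at this position responds to a change that leaves the count of heavy atoms the same, while the entering group has no hydrogen-bond donor and the leaving group has one. Nothing measured here accounts for the rise.

Read one bond further out, the same change is 4-aminobutyl to 2-(dimethylamino)ethyl, and the compounds shown leave open whether the chain or the amine carries the step. A 4-(dimethylamino)butyl chain on the shared core would separate the two, and compound 1 offers no comparison, with "nd" (no result reported).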